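Working notes: methyl in place of chloro on the amide ring

A few compounds are considered here, and "the series" means these few. Any claim that something is new, unique, unknown or untested is made for them only; others in the source may bear on it.

Measured so far:
compound 1 `COc1ccc2nc(C)cc(OCC(=O)Nc3cccc(Br)c3)c2c1` — in an ADME assay on HepG2 cells (Homo sapiens) for cytotoxicity, read by trypan blue exclusion, with a stated time of 48 h, in the presence of a further agent that is not named here (a lower number here means that less compound is tolerated, a higher number that more compound is tolerated), compound 1 gives > 125000 nM, which is a limit of the assay.
compound 2 `COc1ccc2nc(C)cc(OCC(=O)Nc3ccc(Br)cc3)c2c1` — in this assay compound 2 gives > 125000 nM, again a limit.
compound 3 `COc1ccc2nc(C)cc(OCC(=O)Nc3ccc(Cl)cc3)c2c1` — in this assay compound 3 gives 89900 nM.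

Going by the values given here, compound 3 thus carries the only number in the set; the two bromo compounds sit at the limit of > 125000 nM in this assay, at which 2 of the 3 values shown sit. The step that the two limits leave unreadable from compound 1 to compound 2 cannot be read, since both ends are limits. The steps of an at least 1.3-fold lower number from compound 1 to compound 3 (0.14 log units; that floor lies within the scatter) and an at least 1.3-fold lower number from compound 2 to compound 3 (0.14 log units; that floor lies within the scatter) each have a floor that lies within the scatter, so chloro in place of bromo on the aromatic carbon has not shown a readable effect.

Compound 4 `COc1ccc2nc(C)cc(OCC(=O)Nc3ccc(C)cc3)c2c1` differs from compound 3 by methyl in place of chloro on an aromatic carbon. Among the compounds with values here, no measured step exchanges chloro for methyl; the one step at the same aromatic carbon, an at least 1.3-fold lower number from compound 2 to compound 3 (0.14 log units; that floor lies within the scatter), is the nearest guide, and it shows nothing beyond the scatter. For compound 4 no step beyond the scatter is therefore expected in this assay, with a fair chance that the assay again returns only a limit. Compound 4 is estimated at 110000 nM, within 55000 nM to 200000 nM, which means an expected step of a 1.2-fold higher number from compound 3 to compound 4 (0.09 log units; within the scatter).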

Compound 4, half-maximal cytotoxic concentration: > 149000 nM
Compound 4: no number, only a limit; the forecaster's own chance of this, stated with the estimate: 50%; middle value at least 1.3-fold (0.13 log units) from the limit.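

In this assay, going by these compounds alone, methyl in place of chloro on this aromatic carbon, para to a large group, gives an at least 1.6-fold higher number from compound 3 to compound 4 (0.21 log units; that floor lies within the scatter), the first step to exchange a halogen for a carbon group at this position, and even so it does not establish an effect of the change. Within the data shown here, compound 4 gives > 149000 nM, which is a limit of the assay, so compound 3 still carries the only number, and the limits now stand at two different heights: the limit of > 149000 nM in this assay, at which 1 of the 4 values shown sits. The steps from compound 1 to compound 4 and from compound 2 to compound 4 cannot be read, since both ends are limits, so bromo and methyl cannot be ordered.

As far as these compounds go, the true values of compound 1, compound 2 and compound 4 remain unknown, which leaves the bromo, chloro and methyl groups without a readable order in this assay. From the compounds shown here alone, whether an amine, a carboxylic acid or a longer chain such as butyl at this carbon would give a step beyond the scatter also remains open.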